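Taking the methyl off the oxygen: compound 2 to compound 3

The source may report more compounds than this note shows. Statements on the series, on what has been measured and on what is new or still open speak of the compounds shown alone.

Measured in an ADME assay for pharmacokinetics, read by LC-MS, in phosphate buffer, with a stated time of 120 min, at pH 7.4, tested at 1 uM, in the presence of a further agent that is not named here; on this read-out lower numbers stand for a shorter-lived compound and higher numbers for a longer-lived compound:
- compound 1 `C=C(CCO)C(=O)Nc1ccccc1`: > 8.53 h (a limit)
- compound 2 `C=C(COC)C(=O)Nc1ccccc1`: 4.02 h

Going by the values given here, compound 2 gives the only true number so far, 4.02 h. The entry for compound 1, > 8.53 h, is a limit. Compound 3 `C=C(CO)C(=O)Nc1ccccc1` carries hydrogen in place of methyl on an oxygen on a saturated carbon, hydrogen in place of methyl on an oxygen on a saturated carbon. Among the compounds with values here, the only measured step that bears on this is an at least 2.1-fold lower number from compound 1 to compound 2 (0.32 log units; beyond the scatter). That step also alters the chain, so it suggests a direction but no firm size. A small rise in this assay is therefore expected, with the estimated step of a 1.2-fold higher number from compound 2 to compound 3 (0.09 log units; within the scatter) staying within the scatter. Compound 3 is estimated at 5 h, with an expected range of 2.5 h to 9 h.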

Compound 3, half-life: > 8.53 h
Compound 3 gave a limit, no number (the forecaster's own chance of this, stated with the estimate: 10%); middle value at least 1.7-fold (0.23 log units) away from the limit.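

In this assay, hydrogen in place of methyl on an oxygen on a saturated carbon gives an at least 2.1-fold higher number from compound 2 to compound 3 (0.32 log units; beyond the scatter) and, unlike the earlier step, leaves the chain unchanged, so this one change alone moves the read-out beyond the scatter. Among the compounds shown, only the methoxy of compound 2 gives a true number rather than a limit: the limit of > 8.53 h in this assay, at which 2 of the 3 values shown sit.

The step from compound 1 to compound 3 cannot be read, as both entries are limits. On these data alone, whether an amine or a carboxylic acid in place of the hydroxy would also reach the limit stays open.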